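The source may hold more compounds than are shown below. What is called first, only, known or untested is meant among the compounds shown, and "the series" means these compounds.

Measured so far in an assay on isolated protein for inhibition of Amine oxidase [flavin-containing] A (Homo sapiens), read by fluorescence, with stated times of 15 min and 20 min; on this read-out higher numbers stand for weaker inhibition and lower numbers for stronger inhibition:
compound 1 `CC(C)(C)c1cc(CCC(=O)NC2CCN(Cc3ccccc3)CC2)cc(C(C)(C)C)c1O` gives 90200 nM
compound 2 `CC(C)(C)c1cc(/C=C/C(=O)NC2CCN(Cc3ccccc3)CC2)cc(C(C)(C)C)c1O` gives 42500 nM
compound 3 `CC(C)(C)c1cc(/C=C/C(=O)NCCC2CCN(Cc3ccccc3)CC2)cc(C(C)(C)C)c1O` gives 62300 nM

All three share the same core and differ only in the linker between the phenol and the amide and in the spacer to the piperidine. The number for compound 3 in this assay lies within the usual scatter of both compound 1 and compound 2, so on these numbers the three cannot be told apart. Compound 4 `CC(C)(C)c1cc(/C=C/C(=O)NCCC2CCN(Cc3ccccc3F)CC2)cc(C(C)(C)C)c1O` differs from compound 3 in one place: fluoro in place of hydrogen on an aromatic carbon. Within the data shown here, no measured pair shows this kind of change, so the data give no direction for it. Given how small the change is, the expected step is a 1.1-fold lower number from compound 3 to compound 4 (0.05 log units; within the scatter), nothing beyond the scatter. Compound 4 is therefore estimated at 55000 nM, with a likely range from 25000 nM to 130000 nM.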

Compound 4, half-maximal inhibitory concentration: 60200 nM
Beside the measured number, compound 4's estimate is 1.1-fold (0.04 log units) below it, within the range that was stated.
By their numbers in this assay, from the lowest: compounds 2, 4, 3 and 1 (each within the scatter of the next, the first and the last beyond it).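

Among these compounds, changing benzyl to 2-fluorobenzyl gives the first direct reading of this kind of change. In this assay it is a 1.0-fold lower number from compound 3 to compound 4 (0.01 log units; within the scatter), so a fluoro at this place on the aromatic ring leaves the number within the scatter. No supporting measurement bears on why this is so.

On these data alone, whether a larger group at this same place, such as a methoxy or an amine, would shift the number remains open. This single pair also cannot show whether fluoro would behave the same way on the shorter-spacer compound 2.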